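A Methoxyphenyl Variant Tested for Cytotoxicity

The source may hold more compounds than are shown below. What is called first, only, known or untested is meant among the compounds shown, and "the series" means these compounds.

Compound 1, `O=C1N=C(NN2Cc3ccccc3N=C2c2ccccc2)S/C1=C/c1ccc(Br)cc1`: 21300 nM
Compound 2, `O=C1N=C(NN2Cc3ccccc3N=C2c2ccccc2)S/C1=C/c1ccc(O)cc1O`: 3220 nM

Both were measured in a functional assay on A549 cells (Homo sapiens) for cytotoxicity, read by MTT assay, with a stated time of 4 h; on this read-out lower numbers stand for stronger inhibition and higher numbers for weaker inhibition. Compound 2 gives the lowest of the two numbers; the nearest is compound 1, and the step of a 6.6-fold lower number from compound 1 to compound 2 (0.82 log units; beyond the scatter) separates them. Compound 3, `COc1ccc(/C=C2/SC(NN3Cc4ccccc4N=C3c3ccccc3)=NC2=O)cc1`, differs from compound 2 by 4-methoxyphenyl in place of 2,4-dihydroxyphenyl on a double-bonded chain carbon bound to a double-bonded ring carbon. Within the data shown here, only one measured step bears on this change: a 6.6-fold lower number from compound 1 to compound 2 (0.82 log units; beyond the scatter), in which a phenyl bearing two hydroxyls replaced a phenyl bearing a bromine and gave a modestly lower number. Compound 3 carries neither the two hydroxyls of compound 2 nor the bromine of compound 1, so that step is only a loose guide; a number higher than that of compound 2 and nearer that of compound 1 is expected. For compound 3 the estimate in this assay is 10000 nM, with a range from 3000 nM to 35000 nM, meaning an expected step of a 3.1-fold higher number from compound 2 to compound 3 (0.49 log units; beyond the scatter).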

Compound 3, half-maximal inhibitory concentration: 5310 nM
The estimate for compound 3 lay 1.9-fold (0.27 log units) above the measured number; low and high end bracket the measured number.
By their numbers in this assay, from the lowest: compounds 2 and 3 (each within the scatter of the next); then compound 1.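

In this assay, the step of a 1.6-fold higher number from compound 2 to compound 3 (0.22 log units; within the scatter) shows that 4-methoxyphenyl can take the place of 2,4-dihydroxyphenyl on this double-bonded chain carbon without a change beyond the scatter, although the entering group has 0 hydrogen-bond donors and the leaving group has 2. The step of a 4.0-fold lower number from compound 1 to compound 3 (0.60 log units; beyond the scatter), with methoxy in place of bromo on an aromatic carbon, shows that the gain over compound 1 does not depend on having the two hydroxyls. No measured evidence is available to explain either result. The compounds shown leave open whether a plain phenyl, a 4-hydroxyphenyl or a 4-aminophenyl would fall with compound 2 and compound 3 or nearer compound 1. They also leave open whether the same picture would hold in other cell types.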